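Furan-3-yl in place of 2-methylphenyl on the shared core

The source may report more compounds than this note shows. Statements on the series, on what has been measured and on what is new or still open speak of the compounds shown alone.

Compound 1 `Nc1ncnn2c([C@@H]3O[C@H](CO)[C@@H](O)[C@H]3O)cc(C#CC3CC3)c12` with 50 nM as measured
Compound 2 `Cc1ccccc1-c1cc([C@@H]2O[C@H](CO)[C@@H](O)[C@H]2O)n2ncnc(N)c12` with > 100000 nM as a limit

In a functional assay on HCT-116 cells (Homo sapiens) for antiproliferative activity, with a stated time of 72 h (on this read-out higher numbers stand for weaker inhibition and lower numbers for stronger inhibition), compound 1 reads 50 nM as a number. Compound 2 reads > 100000 nM and this is a limit of the assay, not a number. The change to compound 3 `Nc1ncnn2c([C@@H]3O[C@H](CO)[C@@H](O)[C@H]3O)cc(-c3ccoc3)c12` is furan-3-yl in place of 2-methylphenyl on an aromatic carbon. Among the compounds with values here, the one measured step at this carbon is an at least 2000-fold higher number from compound 1 to compound 2 (3.30 log units; beyond the scatter) and it is large, so the group there can move the read-out greatly. A large step towards stronger inhibition is therefore expected in this assay for this change. The estimate is an at least 330-fold lower number from compound 2 to compound 3 (2.52 log units; beyond the scatter) as expected size. For compound 3 the estimated value is 300 nM with an expected range from 30 nM to 5000 nM around it.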

Compound 3, half-maximal inhibitory concentration: 1400 nM
Compound 3: the middle estimate sits 4.7-fold (0.67 log units) below what was measured; measured number inside the range.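

In this assay, furan-3-yl gives a measurable value at this aromatic carbon where 2-methylphenyl does not, with an at least 71-fold lower number from compound 2 to compound 3 (1.85 log units; beyond the scatter). Compound 2 gives a limit of the assay, not a number: the limit of > 100000 nM in this assay, at which 1 of the 3 values shown sits. Furan-3-yl still does not match 2-cyclopropylethynyl, with a 28-fold higher number from compound 1 to compound 3 (1.45 log units; beyond the scatter), so the two aromatic rings are far apart, and neither reaches the alkyne.

The compounds shown leave open whether the ring oxygen, the ring size or the methyl separates compound 3 from compound 2; an unsubstituted phenyl would bear on that. They also leave open how an amine or a longer alkyne chain would read at this carbon.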